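This account rests on a few compounds, and the source may have more. Where it says the series, first, only, none or still open, it means among the compounds named here.

Working notes on the series, step from compound 3 to compound 4.

Three analogues sharing one core have been measured in a functional assay on KM12 cells (Homo sapiens) for inhibition, read by sulforhodamine B assay, with a stated time of 48 h, tested at 10 uM; on this read-out higher numbers stand for more inhibition at the one concentration tested (going by the name of the read-out) and lower numbers for less inhibition. Compound 1 `c1ccc(-c2cn3ccnc3c(-c3ccc4ncn(C5CCCCC5)c4c3)n2)cc1` gives 49%. Compound 2 `COc1ccccc1-c1cn2ccnc2c(-c2ccc3ncn(C4CCCCC4)c3c2)n1` gives 3.58%, and compound 3 `Fc1ccccc1-c1cn2ccnc2c(-c2ccc3ncn(C4CCCCC4)c3c2)n1` gives 2.45%. Compound 3 thus holds the lowest of the three numbers, though the gap to compound 2 is within the scatter; the gap to compound 1 is large, as the step of a number 46.6 percentage points lower from compound 1 to compound 3 (beyond the scatter) shows.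

Compound 4 `FC(F)(F)c1cccc(-c2cn3ccnc3c(-c3ccc4ncn(C5CCCCC5)c4c3)n2)c1` is not yet measured. It differs from compound 3 by 3-(trifluoromethyl)phenyl in place of 2-fluorophenyl on an aromatic carbon.

Bearing on this step: the step of a number 46.6 percentage points lower from compound 1 to compound 3 (beyond the scatter) was large, and the step of a number 1.1 percentage points lower from compound 2 to compound 3 (within the scatter) was within the scatter, so the two substituted phenyl analogues sit together at low inhibition while the bare phenyl of compound 1 sits high. Compound 4 carries a substituted phenyl as well, though at a different position and with a larger group, so a level near compound 3 is expected, with no step beyond the scatter, a number 7.6 percentage points higher from compound 3 to compound 4 (within the scatter). The estimate for compound 4 is 10%, within 0% to 40%.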

Compound 4, a percentage reported as inhibition, at one concentration (the size of the read-out at that concentration, not a potency): 1.25%
The estimate for compound 4 lay 8.8 percentage points above the measured number; the measured number falls inside the stated range.
By their numbers in this assay, from the lowest: compounds 4, 3 and 2 (each within the scatter of the next); then compound 1.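

In this assay the 3-(trifluoromethyl)phenyl of compound 4 stays with the other substituted phenyl analogues, as a number 1.2 percentage points lower from compound 3 to compound 4 (within the scatter) and a number 2.3 percentage points lower from compound 2 to compound 4 (within the scatter) show. Its step from the unsubstituted phenyl, a number 47.8 percentage points lower from compound 1 to compound 4 (beyond the scatter), is large, so among the compounds shown the low level is not confined to the 2-fluorophenyl and 2-methoxyphenyl groups and extends to a group with a different substitution position and more heavy atoms; no listed compound goes against this. No available evidence accounts for the low level of all three substituted compounds.

From the compounds shown here alone, whether any substituent on this phenyl can keep the level of compound 1 remains open. An amine or a carboxylic acid on the ring would test whether the low level extends beyond fluoro, methoxy and trifluoromethyl.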